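A few compounds are considered here, and "the series" means these few. Any claim that something is new, unique, unknown or untested is made for them only; others in the source may bear on it.

Measured in an ADME assay on BJ cells (Homo sapiens) for cytotoxicity, read by luminescence, with a stated time of 72 h; on this read-out lower numbers stand for an effect already at smaller amounts and higher numbers for an effect only at larger amounts of compound:

- Compound 1 `CCOC(=O)c1c(-c2cccc(OC(F)(F)F)c2)[nH]c2cc(OC)ccc2c1=O`: > 21500 nM
- Compound 2 `CCOC(=O)c1c(-c2cccc(OC(F)(F)F)c2)[nH]c2cc(OC(F)(F)F)ccc2c1=O`: > 21500 nM
- Compound 3 `CCOC(=O)c1c(-c2cccc(OC)c2)[nH]c2cc(C(F)(F)F)ccc2c1=O`: > 21500 nM

Each of these values is a limit of the assay and not a number. Compound 3 therefore has no exact position, and it ends at the limit of > 21500 nM in this assay, at which 3 of the 3 values shown sit.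

Compound 4 `CCOC(=O)c1c(-c2cccc(OC(F)(F)F)c2)[nH]c2cc(C(F)(F)F)ccc2c1=O` differs from compound 3 by turning methoxy into trifluoromethoxy: trifluoromethyl in place of methyl on an oxygen on an aromatic ring. Going by the values given here, the one measured step with this change is a step that the two limits leave unreadable from compound 1 to compound 2, so it gives no size to carry over. Even so, compound 2 carries this change and still shows the limit of > 21500 nM. No shift in either direction beyond the usual scatter is therefore expected in this assay, and another limit is the likeliest result. The expected step is a number no higher from compound 3 to compound 4 (the limit leaves the size open). For compound 4 the estimate is 21500 nM, with an expected range from 11000 nM to 43000 nM.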

Compound 4, half-maximal effective concentration: > 21500 nM
Compound 4: only a limit was reported (the forecaster's own chance of this, stated with the estimate: 85%); the middle value lies on the limit itself.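

No step from compound 1, compound 2 or compound 3 to compound 4 can be read, as each value is a limit and not a number: the limit of > 21500 nM in this assay, at which 4 of the 4 values shown sit.

In this assay the compounds shown leave open at what amount each would show an effect, and whether these changes shift that amount at all.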